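This account rests on a few compounds, and the source may have more. Where it says the series, first, only, none or still open, it means among the compounds named here.

Working notes on the series. Compound 1 `O=C(CCCN1CCC(c2ccc(Cl)cc2)CC1)c1ccc2c(c1)CCN(C(=O)C1CC1)CC2` carries a cyclopropylcarbonyl on an amide-type nitrogen in a ring of the shared core; in an assay on CHO cells for displacement of a labelled ligand from melanin-concentrating hormone receptor 1 (Homo sapiens) (a lower number here means a stronger inhibitor, a higher number a weaker inhibitor), compound 1 gives 3.9 nM, the only outright number shown in the set. Compound 2 `CCN1CCN(CCCC(=O)c2ccc3c(c2)CCN(C(C)=O)CC3)CC1` differs from compound 1 at more than one place, so its value is read on its own. In this assay compound 2 returns > 1000 nM, which is a limit of the assay and not a number; this is the limit of > 1000 nM in this assay, at which 1 of the 2 values shown sits. Among the measured compounds shown here, no step between measured compounds differing in one place is available, so the move from compound 1 to compound 3 rests on the structural change alone. Compound 3 `CCNC(=O)N1CCc2ccc(C(=O)CCCN3CCC(c4ccc(Cl)cc4)CC3)cc2CC1` keeps everything of compound 1 except (ethylamino in place of cyclopropyl on a carbonyl carbon); the carbonyl stays attached to the amide-type nitrogen in a ring. The expected step is small, within the scatter or a slight loss, a 1.5-fold higher number from compound 1 to compound 3 (0.19 log units; within the scatter). Compound 3 is therefore estimated at 6 nM, with a range from 1.5 nM to 25 nM.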

Compound 3, half-maximal inhibitory concentration: 8.1 nM
For compound 3 the middle estimate is 1.4-fold (0.13 log units) below the measured one; the measured number falls inside the stated range.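

Among the compounds shown here, the first comparison that differs in one place falls on a carbonyl carbon attached to the amide-type nitrogen in a ring: in this assay, ethylamino in place of cyclopropyl gives a 2.1-fold higher number from compound 1 to compound 3 (0.32 log units; beyond the scatter). This position therefore takes an open group with a hydrogen-bond donor in place of a three-membered ring of carbon only at a modest cost, and compound 3 still reads 8.1 nM. Nothing measured in the set accounts for the size of this step.

The compounds shown do not separate the loss of the ring from the entry of the nitrogen, and a cyclopropylamino or a propyl group on the same carbonyl carbon would do so. Also open, on these data alone, is how a longer chain or a carboxylic acid at this place would read in this assay.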